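Swapping the amide ring: clearance outlook for compound 3

The source may report more compounds than this note shows. Statements on the series, on what has been measured and on what is new or still open speak of the compounds shown alone.

Measured so far, in an ADME assay on microsomes from liver (Mus musculus) for metabolic stability, read by LC-MS, using NADPH, with a stated time of 45 min, tested at 0.5 uM; on this read-out lower numbers stand for slow clearance and higher numbers for fast clearance:
compound 1 `O=C(CCSc1nc2cc(Cl)ccc2o1)N1CCCCC1`: 128 mL/min/g
compound 2 `CC1CCN(C(=O)CCSc2nc3cc(Cl)ccc3o2)C1`: 90.7 mL/min/g

Compound 2 has the lowest of the two numbers; its nearest neighbour is compound 1, with a 1.4-fold lower number from compound 1 to compound 2 (0.15 log units; within the scatter). Compound 3 `O=C(CCSc1nc2cc(Cl)ccc2o1)N1CCS(=O)(=O)C1` is not yet measured. It differs from compound 2 by 1,1-dioxo-1,3-thiazolidin-3-yl in place of 3-methylpyrrolidin-1-yl on a carbonyl carbon. Among the compounds with values here, the only step seen so far, the one from compound 1 to compound 2, changed the ring on the carbonyl carbon and stayed within the scatter, so for compound 3 no step beyond the scatter is expected in this assay. Compound 3 is therefore estimated at 65 mL/min/g, between 30 mL/min/g and 140 mL/min/g, which would mean an expected 1.4-fold lower number from compound 2 to compound 3 (0.14 log units; within the scatter).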

Compound 3, intrinsic clearance in a liver preparation (reported as CLH), per the amount of preparation that the assay uses: 8.9 mL/min/g
Beside the measured number, compound 3's estimate is 7.3-fold (0.86 log units) above it; the whole stated range lies above it.
By their numbers in this assay, from the lowest: compound 3; then compounds 2 and 1 (each within the scatter of the next).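

In this assay the ring on the carbonyl carbon proves able to shift the number strongly: 1,1-dioxo-1,3-thiazolidin-3-yl gives a 10-fold lower number from compound 2 to compound 3 (1.01 log units; beyond the scatter) in place of 3-methylpyrrolidin-1-yl, and a 14-fold lower number from compound 1 to compound 3 (1.16 log units; beyond the scatter) in place of piperidin-1-yl. So this position is not as indifferent as the first pair of rings suggested, since those two stayed within the scatter of each other. Nothing available here explains the drop.

As far as these compounds go, it remains open whether the sulfur with its two oxygens is what counts, or whether the ring as a whole does. A morpholine ring or a six-membered 1,1-dioxothiomorpholine ring on the same carbonyl carbon would help separate the two.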